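The source may hold more compounds than are shown below. What is called first, only, known or untested is meant among the compounds shown, and "the series" means these compounds.

Going by the values given here, compound 1 `CCC(=O)N1CCC(NS(=O)(=O)c2ccc(NC(=O)c3ccccc3C)c3ccccc23)CC1` holds the lower, that is stronger, of the two numbers measured so far in an assay on L1.2 cells for binding affinity to C-C chemokine receptor type 8 (Homo sapiens); a lower number here means a stronger inhibitor, a higher number a weaker inhibitor: compound 1 gives 2.5 nM. Compound 2 `CCOC(=O)N1CCC(NS(=O)(=O)c2ccc(NC(=O)N3CCCCC3)c3ccccc23)CC1` gives 126 nM, a gap well beyond the usual scatter. Compound 3 `CCCC(=O)N1CCC(NS(=O)(=O)c2ccc(NC(=O)c3ccccc3C)c3ccccc23)C1` is made from compound 1 by a single change, keeping the same atoms joined differently: 1-(propylcarbonyl)pyrrolidin-3-yl in place of 1-propanoylpiperidin-4-yl on a sulfonamide nitrogen. No comparable change appears among the measured compounds, so the size of the step cannot be read from them. A modest weakening is expected, with the step of a 3.2-fold higher number from compound 1 to compound 3 (0.51 log units; beyond the scatter). Compound 3 is estimated at 8 nM, with a range from 2 nM to 40 nM.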

Compound 3, inhibition constant: 34.3 nM
Compound 3: the middle estimate sits 4.3-fold (0.63 log units) below what was measured; measured number inside the range.
By their numbers in this assay, from the lowest: compound 1; then compound 3; then compound 2.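

In this assay, the group on the sulfonamide nitrogen proves sensitive: 1-(propylcarbonyl)pyrrolidin-3-yl in place of 1-propanoylpiperidin-4-yl gives a 14-fold higher number from compound 1 to compound 3 (1.14 log units; beyond the scatter). The two groups hold the same atoms, so joining them differently is enough to produce a large loss of binding strength. No supporting measurement accounts for the size of this step.

Going by these compounds, the change alters the ring and the chain on its nitrogen together, so which of them matters remains open. A propanoyl group on the five-membered ring, or a propylcarbonyl group on the six-membered ring, would separate the two.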